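Removing the pyrazine methyl on a fluoroquinoline amide

The source may hold more compounds than are shown below. What is called first, only, known or untested is meant among the compounds shown, and "the series" means these compounds.

This study follows a small set of amides of a quinoline bearing a pyrazine carboxamide, tested in a functional assay on MIA PaCa-2 cells (Homo sapiens) for inhibition, read by MTT assay, with a stated time of 72 h; on this read-out higher numbers stand for weaker inhibition and lower numbers for stronger inhibition. Compound 1 `Cc1cnc(C(=O)Nc2cccc3ccc(C)nc23)cn1` carries a methyl on each ring system. In this assay compound 1 reaches only a limit, > 10000 nM. Compound 3 `Cc1ccc2cccc(NC(=O)c3cnccn3)c2n1` lacks the methyl on the pyrazine; the change from compound 1 to compound 3 is hydrogen in place of methyl on an aromatic carbon. In this assay compound 3 also reaches only a limit, > 10000 nM. The step that the two limits leave unreadable from compound 1 to compound 3 therefore cannot be read, because both values sit at the limit of > 10000 nM in this assay, at which 2 of the 3 values shown sit.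

Compound 2 `Cc1cnc(C(=O)Nc2cc(F)cc3cccnc23)cn1` has a different core, with a fluorine on the quinoline and no methyl there; how its core differs from that of compound 1 is not broken down here. In this assay, going by the values given here, compound 2 gives 310 nM, the only number obtained in the set.

Compound 4 `O=C(Nc1cc(F)cc2cccnc12)c1cnccn1` is the unmeasured partner of compound 2, made by the same change seen before: hydrogen in place of methyl on an aromatic carbon. Since the earlier step from compound 1 to compound 3 is hidden by the two limits, there is no measured guide for the size of this change. The expectation is a modest step, a 2.9-fold higher number from compound 2 to compound 4 (0.46 log units; beyond the scatter), resting on the fact that the loss of the methyl occurs in the same place as from compound 1 to compound 3 but on the core that gave a real number in compound 2. Compound 4 is therefore estimated at 900 nM in this assay, expected to fall between 200 nM and 5000 nM.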

Compound 4, half-maximal inhibitory concentration: 130 nM
Estimate against measurement, compound 4: 6.9-fold (0.84 log units) above; the whole stated range lies above it.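

In this assay, the change from 5-methylpyrazin-2-yl to pyrazin-2-yl on the fluorine-bearing core gives a 2.4-fold lower number from compound 2 to compound 4 (0.38 log units; beyond the scatter), so on this core the unsubstituted pyrazine goes with the stronger inhibition, by a modest margin. The same change on the core of compound 1 cannot be read, because compound 1 and compound 3 both rest on a limit of the assay rather than on a number: the limit of > 10000 nM in this assay, at which 2 of the 4 values shown sit. The series therefore gives one readable instance of this change, on one core, and it shows neither that the gain carries over to the core of compound 1 nor that it fails to do so.

What the compounds shown leave open is how other groups would read in this assay in the place the methyl leaves on the pyrazine, such as an amine, a methoxy group or a longer chain like ethyl. Going by these compounds alone, also open is how the same change from methyl to hydrogen would behave on a core with a chlorine in place of the fluorine, which would test whether the step seen here holds beyond the single pair of compound 2 and compound 4.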